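Amide nitrogen substituent swap in a TRPM8 agonist series

The source may hold more compounds than are shown below. What is called first, only, known or untested is meant among the compounds shown, and "the series" means these compounds.

In an assay on HEK293 cells for agonist activity at transient receptor potential cation channel subfamily M member 8 (Homo sapiens), read by fluorescence and calcium flux, with a stated time of 15 min (on this read-out lower numbers stand for an effect already at smaller amounts and higher numbers for an effect only at larger amounts of compound), compound 1 `CON(Cc1cccs1)C(=O)COc1ccc(C)cc1` gives 10 nM, compound 2 `Cc1ccc(OCC(=O)N(Cc2cccs2)c2ccncc2)cc1` gives 52 nM, and compound 3 `Cc1ccc(OCC(=O)N(Cc2cccs2)c2ccccc2)cc1` gives 23 nM. Within these three, compound 3 holds the second highest number: relative to compound 1 the step is a 2.3-fold higher number from compound 1 to compound 3 (0.36 log units; beyond the scatter), and relative to compound 2 it is a 2.3-fold lower number from compound 2 to compound 3 (0.35 log units; beyond the scatter). Compound 4 `Cc1ccc(OCC(=O)N(Cc2cccs2)c2c(C)n[nH]c2C)cc1` differs from compound 3 in one place, (3,5-dimethyl-1H-pyrazol-4-yl in place of phenyl on an amide-type nitrogen). Among the measured compounds shown here, two measured steps touch this position. The replacement of methoxy by phenyl gave a 2.3-fold higher number from compound 1 to compound 3 (0.36 log units; beyond the scatter), and the replacement of pyridin-4-yl by phenyl gave a 2.3-fold lower number from compound 2 to compound 3 (0.35 log units; beyond the scatter). Both show that changing the group on the amide-type nitrogen moves this assay only modestly, and the single heteroaromatic ring measured so far, in compound 2, stands above the phenyl of compound 3. For compound 4, which also carries a heteroaromatic ring at this nitrogen, a modest rise is therefore expected, about a 2.2-fold higher number from compound 3 to compound 4 (0.34 log units; beyond the scatter). Compound 4 is accordingly estimated at 50 nM, with a range from 18 nM to 150 nM.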

Compound 4, half-maximal effective concentration: 0.3 nM
Estimate against measurement, compound 4: 170-fold (2.22 log units) above; measured number outside the range, below it.
By their numbers in this assay, from the lowest: compound 4; then compound 1; then compound 3; then compound 2.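

Among the compounds shown here, the amide-type nitrogen proves far more sensitive in this assay than the earlier compounds indicated, with a 77-fold lower number from compound 3 to compound 4 (1.88 log units; beyond the scatter) on replacing phenyl and a 170-fold lower number from compound 2 to compound 4 (2.24 log units; beyond the scatter) on replacing pyridin-4-yl as the two large steps at this position. A heteroaromatic ring as such therefore does not set the direction, since pyridin-4-yl and 3,5-dimethyl-1H-pyrazol-4-yl fall on opposite sides of phenyl. Compound 2 and compound 3 both stand above compound 1, whereas 3,5-dimethyl-1H-pyrazol-4-yl gives a 33-fold lower number from compound 1 to compound 4 (1.52 log units; beyond the scatter) in place of methoxy, and no supporting data bear on the origin of this gain.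

The shown compounds do not separate the contribution of the pyrazole ring from that of its two methyl groups. Unsubstituted 1H-pyrazol-4-yl and 1-methylpyrazol-4-yl at this nitrogen would address that question.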